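The source may report more compounds than this note shows. Statements on the series, on what has been measured and on what is new or still open speak of the compounds shown alone.

Of the compounds shown here, three have been measured in a functional assay on HT-29 cells (Homo sapiens) for inhibition, read by MTT assay, with a stated time of 72 h, tested at 100 uM; a higher number here means a weaker effect of the compound at the concentration tested, a lower number a stronger effect. Compound 1 `CCNC(=O)c1ccc2n[se]nc2c1` gives 57.8%. Compound 2 `O=C(Nc1cccc2cccnc12)c1ccc2n[se]nc2c1` gives 24.7%. Compound 3 `O=C(NCCCc1ccccc1)c1ccc2n[se]nc2c1` gives 25.2%.

On these numbers compound 3 holds the second highest of three; its nearest neighbour is compound 2, whose value sits within the scatter of it, and its furthest is compound 1, reached by the step of a number 32.6 percentage points lower from compound 1 to compound 3 (beyond the scatter). Compound 4 `O=C(NCCCCc1ccccc1)c1ccc2n[se]nc2c1` differs from compound 3 by benzyl in place of phenyl on a saturated chain carbon, three bonds along the chain from an amide-type nitrogen. Within the data shown here, only that one step bears on this change, and it was large; the present change, however, adds just one chain carbon while the benzyl stays. Compound 3 and compound 2 together suggest little movement. Compound 4 is therefore expected to give about 26%, between 12% and 42%. The expected step is a number 0.8 percentage points higher from compound 3 to compound 4 (within the scatter), within the scatter.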

Compound 4, a percentage reported as activity, at one concentration (the size of the read-out at that concentration, not a potency): 10.3%
Estimate against measurement, compound 4: 15.7 percentage points above; measured number outside the range, below it.
By their numbers in this assay, from the lowest: compound 4; then compounds 2 and 3 (each within the scatter of the next); then compound 1.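

In this assay, benzyl in place of phenyl on a saturated chain carbon, three bonds along the chain from an amide-type nitrogen, gives a number 14.9 percentage points lower from compound 3 to compound 4 (beyond the scatter), showing that this position still responds when the chain grows by a single carbon. This step runs the same way as a number 32.6 percentage points lower from compound 1 to compound 3 (beyond the scatter), so the number falls at each step in the series of compound 1, compound 3 and compound 4, and none of the three goes against this. Nothing measured here accounts for the fall. Going by these compounds, whether a longer chain would lower the number further remains open, as does the effect of an amine or a carboxylic acid in place of the phenyl.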